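Hydroxyphenyl in Place of Chlorophenyl: What Compound 4 May Give

The source may report more compounds than this note shows. Statements on the series, on what has been measured and on what is new or still open speak of the compounds shown alone.

In a functional assay on HepG2 cells (Homo sapiens) for inhibition, read by MTT assay, with a stated time of 72 h (on this read-out higher numbers stand for weaker inhibition and lower numbers for stronger inhibition), compound 3 `C#CCSc1nc(Nc2ccc(Cl)cc2)c2ccncc2n1` gives 36700 nM, the highest of the two numbers shown. Compound 2 `C#CCSc1nc(Nc2ccc(C)cc2)c2ccncc2n1` gives 6170 nM in this assay. In this assay compound 1 `C#CCSc1nc(NCCC(C)C)c2ccncc2n1` sits at the limit > 80000 nM. Going by the values given here, the step of a 5.9-fold higher number from compound 2 to compound 3 (0.77 log units; beyond the scatter) is the only comparison between two aryl groups, while an at least 12-fold lower number from compound 1 to compound 2 (1.11 log units; beyond the scatter) and an at least 2.1-fold lower number from compound 1 to compound 3 (0.33 log units; beyond the scatter) show what an aryl group brings over isopentyl. Compound 4 `C#CCSc1nc(Nc2ccccc2O)c2ccncc2n1` carries 2-hydroxyphenyl in place of 4-chlorophenyl on a nitrogen on an aromatic ring. Among the compounds with values here, no measured step touches a hydroxyl group, so the direction is open; the aryl-to-aryl step suggests a change of modest size. Compound 4 is therefore expected to give about 20000 nM, between 4000 nM and 80000 nM. That estimate means an expected step of a 1.8-fold lower number from compound 3 to compound 4 (0.26 log units; within the scatter).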

Compound 4, half-maximal inhibitory concentration: > 80000 nM
Compound 4 was reported as a limit; the forecaster's own chance of this, stated with the estimate: 25%; middle value at least 4.0-fold (0.60 log units) from the limit.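

Compound 4 shows that an aryl group on this nitrogen does not by itself keep the number readable in this assay, and its value is a limit of the assay: the limit of > 80000 nM in this assay, at which 2 of the 4 values shown sit. With 2-hydroxyphenyl on this nitrogen the shared core gives an at least 2.1-fold higher number from compound 3 to compound 4 (0.33 log units; beyond the scatter) and an at least 12-fold higher number from compound 2 to compound 4 (1.11 log units; beyond the scatter). The step from compound 1 to compound 4 cannot be read, as both values are limits.

The compounds shown do not separate the effect of the hydroxyl group from that of its place on the ring. From the compounds shown here alone, how a 4-hydroxyphenyl or a 4-aminophenyl group would read on this nitrogen stays open.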